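This account rests on a few compounds, and the source may have more. Where it says the series, first, only, none or still open, it means among the compounds named here.

Compound 1, `CNCCN(C)c1nnnn1Cc1ccccc1C(F)(F)F`, gives 13% in an assay on cells for inhibition of protein arginine N-methyltransferase 1 (Homo sapiens), read by scintillation counting, with stated times of 15 min and 60 min, tested at 9 uM; a higher number here means more inhibition at the concentration tested (going by the name of the read-out), a lower number less inhibition.
Compound 2, `CNCCN(C)c1nnnn1Cc1ccc(C(F)(F)F)cc1`, gives 2% in this assay.
Compound 3, `CNCCN(C)c1nnnn1Cc1ccc(OC(F)(F)F)cc1`, gives 5% in this assay.

Compound 3 has the second highest of the three numbers. Its nearest neighbour is compound 2, with a number 3 percentage points higher from compound 2 to compound 3 (within the scatter), a step that stays within the scatter. Going by the values given here, no step is computed between compound 1 and compound 3; compound 1 gives 13% and compound 3 gives 5%, and the gap between them also lies within the scatter. All three numbers therefore sit low and close together in this assay.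

Compound 4, `CNCCN(C)c1nnnn1Cc1ccc(OC)cc1`, differs from compound 3 by methyl in place of trifluoromethyl on an oxygen on an aromatic ring. Among the compounds with values here, the only measured step that bears on this change is the one from compound 2 to compound 3, a number 3 percentage points higher from compound 2 to compound 3 (within the scatter), which swapped one fluorinated group for another at the same position of the ring and moved the number only within the scatter. On that basis compound 4 is expected to show no change at the digits printed from compound 3 to compound 4 (within the scatter), a step not expected to exceed the scatter. Compound 4 is estimated at 5%, with a range from -5% to 15%.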

Compound 4, a percentage reported as inhibition, at one concentration (the size of the read-out at that concentration, not a potency): 0%
Estimate against measurement, compound 4: 5 percentage points above, and the stated range covers the measured number.
By their numbers in this assay, from the lowest: compounds 4, 2, 3 and 1 (each within the scatter of the next, the first and the last beyond it).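

Replacing trifluoromethyl with methyl on the oxygen gives a number 5 percentage points lower from compound 3 to compound 4 (within the scatter) in this assay, so taking away all the fluorine from this group leaves the number within the scatter. Methoxy in place of trifluoromethyl on an aromatic carbon gives a number 2 percentage points lower from compound 2 to compound 4 (within the scatter), which adds a group without fluorine to the two fluorinated ones at this place, and none of the three stands apart from the others. Nothing available here accounts for this flat result.

Going by these compounds, whether an amine or a carboxylic acid at this place on the ring, or a longer chain on the oxygen, would bring a step beyond the scatter remains open. With readings at a single concentration, these compounds also leave their potencies undefined.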